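Straight pentyl chain in place of the fluorinated ring

The compounds below may be only part of what the source reports. "The series", "measured", "known", "first", "only" and "open" are said of these compounds alone.

Measured so far:
Compound 1, `C#CC(=O)N1C(C(CC)CCCC)SC[C@@H]1C(=O)OCC`: 1700 nM
Compound 2, `C#CC(=O)N1C(CC(C)CC(C)(C)C)SC[C@@H]1C(=O)OCC`: 1600 nM
Compound 3, `C#CC(=O)N1C(c2ccccc2F)SC[C@@H]1C(=O)OCC`: 1700 nM

All three were tested in a functional assay on Huh-7 cells (Homo sapiens) for inhibition, read by sulforhodamine B assay; a higher number here means a weaker inhibitor, a lower number a stronger inhibitor. On these numbers compound 3 is level with compound 1 at the digits shown, and the two of them are the highest of the three; compound 2 sits only a little lower, and all three lie within the scatter of one another. For the measured compounds named here, the one step with a single change, no change at the digits printed from compound 1 to compound 3 (within the scatter), shows that swapping a branched alkyl chain for a fluorinated aromatic ring left the number where it was.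

Compound 4, `C#CC(=O)N1C(CCCCC)SC[C@@H]1C(=O)OCC`, is the next compound: pentyl in place of 2-fluorophenyl on a saturated ring carbon. It therefore reverses the direction of that earlier swap, putting an unbranched chain where compound 3 has the ring. Since the alkyl-bearing compounds 1 and 2 and the ring-bearing compound 3 all give nearly the same number, no step beyond the scatter is expected here, and no change at the digits printed from compound 3 to compound 4 (within the scatter) is the expected outcome. Compound 4 is estimated at 1700 nM, with a likely range from 800 nM to 3600 nM.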

Compound 4, half-maximal inhibitory concentration: 1800 nM
Beside the measured number, compound 4's estimate is 1.1-fold (0.02 log units) below it; the measured number falls inside the stated range.
By their numbers in this assay, from the lowest: compounds 2, 1, 3 and 4 (each within the scatter of the next).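

Putting an unbranched pentyl chain on this saturated ring carbon in place of the 2-fluorophenyl ring gives a 1.1-fold higher number from compound 3 to compound 4 (0.02 log units; within the scatter) in this assay, so the ring is not needed to hold the number at this level. Trimming the chain's branches makes no readable difference either, with a 1.1-fold higher number from compound 2 to compound 4 (0.05 log units; within the scatter) for butyl in place of 1,3,3-trimethylbutyl, and a 1.1-fold higher number from compound 1 to compound 4 (0.02 log units; within the scatter) for hydrogen in place of ethyl. Nothing available explains why such different groups give matching numbers.

Still open, going by these compounds, is whether any group at this carbon can move the number beyond the scatter, for example an amine, a carboxylic acid or a much longer chain. On these data alone, the ethynylcarbonyl and ethoxycarbonyl groups stay the same in all four compounds, so their contribution also remains open.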